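Demethylation on a chalcone series, tracked by cell proliferation

This account rests on a few compounds, and the source may have more. Where it says the series, first, only, none or still open, it means among the compounds named here.

Compound 1 `COc1cc(OC)c(C(=O)/C=C/c2ccccc2SC)c(OC)c1`, compound 2 `COc1cccc(/C=C/C(=O)c2c(OC)cc(OC)cc2OC)c1` and compound 3 `COc1cc(O)c(C(=O)/C=C/c2ccccc2SC)c(OC)c1` were measured in a functional assay on HaCaT cells (Homo sapiens), read by fluorescence and BrdU incorporation, with a stated time of 48 h, tested at 10 uM; on this read-out lower numbers stand for a stronger effect and higher numbers for a weaker effect at the one concentration tested. There compound 1 gives 24%, compound 2 gives 19% and compound 3 gives 51%. The two cores differ in that compound 2 carries 3-methoxyphenyl in place of 2-(methylsulfanyl)phenyl on a double-bonded chain carbon bound to a double-bonded chain carbon; this gave a number 5 percentage points lower from compound 1 to compound 2 (within the scatter), so the two values cannot be told apart. The change of interest is hydrogen in place of methyl on an oxygen on an aromatic ring, which produced a number 27 percentage points higher from compound 1 to compound 3 (beyond the scatter), a weakening of the effect in this assay.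

Compound 4 `COc1cccc(/C=C/C(=O)c2c(O)cc(OC)cc2OC)c1` has not yet been measured. It differs from compound 2 by hydrogen in place of methyl on an oxygen on an aromatic ring, the same change as between compound 1 and compound 3, at the same kind of place. Because the earlier step was a number 27 percentage points higher from compound 1 to compound 3 (beyond the scatter), a similar step is expected here, giving an estimated a number 26 percentage points higher from compound 2 to compound 4 (beyond the scatter) from compound 2 to compound 4. That the two cores behaved alike in a number 5 percentage points lower from compound 1 to compound 2 (within the scatter) lends some support, though one pair is a thin base. Compound 4 is therefore estimated at 45%, likely between 30% and 62% in this assay.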

Compound 4, a percentage reported as activity, at one concentration (the size of the read-out at that concentration, not a potency): 49%
Beside the measured number, compound 4's estimate is 4 percentage points below it, and the stated range covers the measured number.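

In this assay, the change from methoxy to hydroxy gave a number 30 percentage points higher from compound 2 to compound 4 (beyond the scatter), so the weakening seen on the core of compound 1 recurred on the core of compound 2. Set side by side, the two steps agree in size: the same change on two cores in this assay, a number 27 percentage points higher (beyond the scatter) from compound 1 to compound 3 and a number 30 percentage points higher (beyond the scatter) from compound 2 to compound 4, 3 percentage points apart, within the scatter of two such steps. This shows that the change carried over between these two cores at the one concentration tested, but two pairs are a narrow base, and they do not say why the effect weakens or whether the same step would appear on a further core.

The compounds shown replace the methyl on that oxygen only with hydrogen, so it remains open whether an ethyl group or an acetyl group there would give numbers nearer those of the methoxy compounds or of the hydroxy compounds. Also open, as far as these compounds go, is whether an amine in place of the hydroxy would give a step of similar size on either core.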